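The source may report more compounds than this note shows. Statements on the series, on what has been measured and on what is new or still open speak of the compounds shown alone.

Within the data shown here, in a functional assay on PC-3 cells (Homo sapiens) for inhibition (on this read-out higher numbers stand for weaker inhibition and lower numbers for stronger inhibition), compound 3 `CCn1c(=O)/c(=C2\Sc3ccc(C)cc3N2C)s/c1=C\c1ccncc1Nc1ccccc1F` gives 70 nM, the lowest of the three numbers measured so far. Compound 1 `CCn1c(=O)/c(=C2\Sc3ccccc3N2C)s/c1=C\c1ccncc1Nc1ccccc1F` gives 360 nM, and compound 2 `CCn1c(=O)/c(=C2\Sc3ccc(OC)cc3N2C)s/c1=C\c1ccncc1Nc1ccccc1Cl` gives 760 nM. Among the measured compounds shown here, the one measured step on the same ring, a 5.1-fold lower number from compound 1 to compound 3 (0.71 log units; beyond the scatter), lowered the number clearly beyond the scatter. Compound 4 `CCn1c(=O)/c(=C2\Sc3ccc(OC)cc3N2C)s/c1=C\c1ccncc1Nc1ccccc1F` differs from compound 3 by methoxy in place of methyl on an aromatic carbon. For the measured compounds named here, no measured pair shows methoxy replacing methyl, so this change has no direct precedent among the measured compounds. Compound 2 also carries a methoxy on that ring and gives 760 nM, a number well above that of compound 3, but compound 2 differs from compound 4 in another place as well, so its value can only hint at the direction. The expected change, a 4.3-fold higher number from compound 3 to compound 4 (0.63 log units; beyond the scatter), is therefore an increase in the number, with wide uncertainty. Compound 4 is estimated at 300 nM, with a range from 100 nM to 900 nM.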

Compound 4, half-maximal inhibitory concentration: 100 nM
Compound 4: the middle estimate sits 3.0-fold (0.48 log units) above what was measured; low and high end bracket the measured number.
By their numbers in this assay, from the lowest: compounds 3 and 4 (each within the scatter of the next); then compound 1; then compound 2.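

In this assay, methoxy in place of methyl on this aromatic carbon gives a 1.4-fold higher number from compound 3 to compound 4 (0.15 log units; within the scatter), so on this read-out the two groups cannot be told apart here. Methoxy in place of hydrogen at the same place gives a 3.6-fold lower number from compound 1 to compound 4 (0.56 log units; beyond the scatter), which shows that the earlier drop with methyl, a 5.1-fold lower number from compound 1 to compound 3 (0.71 log units; beyond the scatter), is not confined to methyl. With methoxy held constant, fluoro in place of chloro on the other aromatic ring gives a 7.6-fold lower number from compound 2 to compound 4 (0.88 log units; beyond the scatter), so the high number of compound 2 goes with its chloro rather than its methoxy.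

The data shown offer no measurement that explains these steps. As far as these compounds go, whether an amine, a carboxylic acid or a longer chain such as ethoxy at this place would keep the number as low remains open.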